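A few compounds are considered here, and "the series" means these few. Any claim that something is new, unique, unknown or untested is made for them only; others in the source may bear on it.

Measured in a functional assay on MCF7 cells (Homo sapiens) for cytotoxicity, read by MTT assay, with a stated time of 48 h; a higher number here means a weaker inhibitor, a lower number a stronger inhibitor:
- compound 1 (`Cc1ncc([N+](=O)[O-])n1CCSc1nnc(-c2ccccc2)o1`) gives 20500 nM here
- compound 2 (`COc1ccccc1-c1nnc(SCCn2c([N+](=O)[O-])cnc2C)o1`) gives 10800 nM here
- compound 3 (`Cc1ncc([N+](=O)[O-])n1CCSc1nnc(-c2ccc([N+](=O)[O-])cc2)o1`) gives 12700 nM here

Compound 2 stands level with both other compounds, as all of its gaps to them lie within the scatter. Compound 4 (`Cc1ncc([N+](=O)[O-])n1CCSc1nnc(-c2ccccc2Cl)o1`) is not yet measured. It differs from compound 2 by chloro in place of methoxy on an aromatic carbon, ortho to a large group (chloro in place of methoxy on an aromatic carbon) in the same series.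

Among the measured compounds shown here, two measured steps bear on this exchange. Methoxy in place of hydrogen on an aromatic carbon gave a 1.9-fold lower number from compound 1 to compound 2 (0.28 log units; within the scatter) and nitro in place of hydrogen on an aromatic carbon gave a 1.6-fold lower number from compound 1 to compound 3 (0.21 log units; within the scatter) in this series. For the measured compounds named here, the first concerns the group that leaves, while no measured compound yet shows chloro. Neither step lies beyond the scatter, so no step beyond the scatter is expected in this assay for this exchange. The expected step is a 1.2-fold higher number from compound 2 to compound 4 (0.08 log units; within the scatter) on this reasoning. For compound 4 the estimated value is 13000 nM with an expected range from 6500 nM to 26000 nM in this assay.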

Compound 4, half-maximal inhibitory concentration: 22500 nM
Compound 4: the middle estimate sits 1.7-fold (0.24 log units) below what was measured; the range from low to high includes it.
By their numbers in this assay, from the lowest: compounds 2, 3, 1 and 4 (each within the scatter of the next, the first and the last beyond it).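

In this assay, the exchange of 2-methoxyphenyl for 2-chlorophenyl gives a 2.1-fold higher number from compound 2 to compound 4 (0.32 log units; beyond the scatter), a modest step but the only one in this series that lies beyond the scatter. Chloro in place of hydrogen on the same aromatic carbon gives a 1.1-fold higher number from compound 1 to compound 4 (0.04 log units; within the scatter), so compound 4 stands level with compound 1, and methoxy and chloro separate from each other at this place although neither separates from hydrogen. No measurement at hand accounts for this separation.

On these data alone, it remains open whether an amine or a hydroxyl group on this aromatic carbon would read with methoxy or with chloro. Also open, as far as these compounds go, is whether methoxy and chloro would separate in the same way with a longer chain in the linker of the shared core.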